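A few compounds are considered here, and "the series" means these few. Any claim that something is new, unique, unknown or untested is made for them only; others in the source may bear on it.

Measured compounds in a functional assay on CHO-K1 cells for antagonist activity at Urotensin-2 receptor (Rattus norvegicus), read by FLIPR and calcium flux, with a stated time of 1 h; a lower number here means a stronger inhibitor, a higher number a weaker inhibitor:
compound 1 `CCN1CCN(c2cccc3c2CN([C@H](CCCNCc2cccs2)c2ccc(OC)c(OC)c2)C3=O)CC1`, 6 nM
compound 3 `COc1ccc([C@@H](CCCN(C)S(=O)(=O)c2cccs2)N2Cc3c(cccc3N3CCN(C4CC4)CC3)C2=O)cc1OC`, 13 nM
compound 2 `COc1cc(Br)c(S(=O)(=O)Nc2ccc(C(F)(F)F)c(O[C@@H]3CCN(C)C3)c2)cc1OC`, 34 nM

Compound 1 stands at the lowest of the three numbers. Compound 3 is the nearest, its value beyond the scatter above compound 1; compound 2 is the furthest, also beyond the scatter. Going by the values given here, no step between two measured compounds differing in one place is available, so nothing itself calibrates the move to compound 4.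

Compound 4 `CCN1CCN(c2cccc3c2CN([C@H](CCCNc2cncc(OC)n2)c2ccc(OC)c(OC)c2)C3=O)CC1` differs from compound 1 as follows: 6-methoxypyrazin-2-yl in place of (thiophen-2-yl)methyl on an amine nitrogen. With no comparable change among the measured compounds, the expected step is a modest rise, probably just beyond the scatter, as a 2.5-fold higher number from compound 1 to compound 4 (0.40 log units; beyond the scatter). Compound 4 is estimated at 15 nM, in the range 4 nM to 60 nM.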

Compound 4, half-maximal inhibitory concentration: 4 nM
The estimate for compound 4 lay 3.8-fold (0.57 log units) above the measured number, and the stated range covers the measured number.
By their numbers in this assay, from the lowest: compounds 4 and 1 (each within the scatter of the next); then compound 3; then compound 2.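

In this assay, replacing (thiophen-2-yl)methyl with 6-methoxypyrazin-2-yl on the amine nitrogen gives a 1.5-fold lower number from compound 1 to compound 4 (0.18 log units; within the scatter) and leaves the two compounds level. In the core of compound 1, this position therefore accepts a six-membered aromatic ring joined directly to the amine nitrogen as well as a five-membered one joined through a methylene. No measurement available here bears on why the number holds. Still open, from the compounds shown here alone, is whether the methoxy group contributes, and whether a plain pyridin-2-yl or a benzyl group on the same nitrogen would match these values.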